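Notes on the anilino series: moving the methoxy group

This account rests on a few compounds, and the source may have more. Where it says the series, first, only, none or still open, it means among the compounds named here.

Measured so far in a functional assay on B16-F10 cells (Mus musculus) for inhibition, read by MTT assay, with a stated time of 72 h; a higher number here means a weaker inhibitor, a lower number a stronger inhibitor:
compound 1 `COc1ccccc1Nc1nc(SCc2cn(CC(=O)NC(=O)Nc3ccccn3)nn2)nc(-c2ccc(C(C)C)cc2)c1C#N` — 34600 nM
compound 2 `Cc1ccc(-c2nc(SCc3cn(CC(=O)NC(=O)Nc4ccccn4)nn3)nc(Nc3ccc(C(C)C)cc3)c2C#N)cc1` — 35 nM
compound 3 `COc1ccc(Nc2nc(SCc3cn(CC(=O)NC(=O)Nc4ccccn4)nn3)nc(-c3ccc(C)cc3)c2C#N)cc1` — 8750 nM

Compound 3 stands second highest of the three numbers. Its nearest neighbour is compound 1, which gives 34600 nM in this assay, a higher number; its furthest is compound 2, which gives 35 nM, the lowest number of the set.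

Compound 4 `COc1ccccc1Nc1nc(SCc2cn(CC(=O)NC(=O)Nc3ccccn3)nn2)nc(-c2ccc(C)cc2)c1C#N` is not yet measured. It differs from compound 3 in one place: 2-methoxyphenyl in place of 4-methoxyphenyl on a nitrogen on an aromatic ring. For the measured compounds named here, no measured step covers this change directly. Going by the values given here, the only single-place step in the set is a 250-fold higher number from compound 2 to compound 3 (2.40 log units; beyond the scatter), which concerns the other end of the anilino group and does not bear on where the methoxy group sits. What does bear on it is compound 1, which already carries the 2-methoxyphenyl group entering here and gives 34600 nM, the weakest number in this assay, while compound 3 with the 4-methoxyphenyl group gives 8750 nM; the two differ also in the group on the other aromatic ring, so no clean step can be read.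

For compound 4 an upward step a 2.5-fold higher number from compound 3 to compound 4 (0.40 log units; beyond the scatter) is expected, lying closer to compound 1 than to compound 3. Compound 4 is estimated at 22000 nM, within a range from 7000 nM to 70000 nM.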

Compound 4, half-maximal inhibitory concentration: 8580 nM
Estimate against measurement, compound 4: 2.6-fold (0.41 log units) above; measured number inside the range.
By their numbers in this assay, from the lowest: compound 2; then compounds 4 and 3 (each within the scatter of the next); then compound 1.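

In this assay, a 1.0-fold lower number from compound 3 to compound 4 (0.01 log units; within the scatter), so within this pair, 2-methoxyphenyl in place of 4-methoxyphenyl on the nitrogen leaves the number unchanged within the scatter, and the place of the methoxy group is not a lever here. With 2-methoxyphenyl held fixed, a 4.0-fold lower number from compound 1 to compound 4 (0.61 log units; beyond the scatter), which separates the methyl and isopropyl groups on the aromatic carbon and shows that the 2-methoxyphenyl group alone does not account for the high number of compound 1. The large step of a 250-fold higher number from compound 2 to compound 4 (2.39 log units; beyond the scatter) shows that 4-isopropylphenyl on the nitrogen stands far from the 2-methoxyphenyl group as well as from the 4-methoxyphenyl group, so the low number of compound 2 is tied to the isopropyl-bearing group and not to one methoxy placement.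

Still open, from the compounds shown here alone, is whether this indifference to placement extends to other groups on that ring, such as a hydroxyl, a dimethylamino group or a carboxylic acid, and whether it survives with isopropyl in place of methyl on the other aromatic ring. Nothing available gives a reason for any of these steps.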